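The source may hold more compounds than are shown below. What is called first, only, known or untested is meant among the compounds shown, and "the series" means these compounds.

Two compounds of this series have been run in an ADME assay on MT4 cells (Homo sapiens) for cytotoxicity, read by MTT assay; a lower number here means that less compound is tolerated, a higher number that more compound is tolerated. Compound 1 `Cc1cc(C)cc(S(=O)(=O)c2c(C(=O)Nc3ccnc(C#N)c3)[nH]c3ccc(Cl)cc23)c1` gives 6840 nM. Compound 2 `Cc1cc(C)cc(S(=O)(=O)c2c(C(=O)NC(C)c3ccccc3F)[nH]c3ccc(Cl)cc23)c1` does not give a number in this assay but only a limit, > 51500 nM, so only a bound is known for it. Its value is the limit of > 51500 nM in this assay, at which 1 of the 2 values shown sits. Among the compounds with values here, the one measured step, an at least 7.5-fold higher number from compound 1 to compound 2 (0.87 log units; beyond the scatter), therefore leaves compound 2 standing at the upper edge of what the numbers show.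

Compound 3 `Cc1cc(C)cc(S(=O)(=O)c2c(C(=O)NCC(=O)NCc3ccccc3F)[nH]c3ccc(Cl)cc23)c1` follows from compound 2 through a single change: ((2-fluorobenzyl)carbamoyl)methyl in place of 1-(2-fluorophenyl)ethyl on an amide-type nitrogen. Within the data shown here, no measured step concerns an exchange of this kind; the only step in hand swaps 2-cyanopyridin-4-yl for 1-(2-fluorophenyl)ethyl, and compound 2, which carries that group, already sits at the limit. With nothing in the data pointing the other way, the expectation for compound 3 is a number near the same limit, so an at least 1.1-fold lower number from compound 2 to compound 3 (0.05 log units; that floor lies within the scatter) is the step expected, within the scatter. Compound 3 is accordingly estimated at 45000 nM, in the range 15000 nM to 60000 nM, with a fair chance that again only a limit is reported.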

Compound 3, half-maximal cytotoxic concentration: > 47300 nM
Compound 3: only a limit was reported (the forecaster's own chance of this, stated with the estimate: 60%); at least 1.0-fold (0.02 log units) between middle value and limit.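

In this assay compound 3 also gives only a limit, > 47300 nM, so a second and larger group on this amide-type nitrogen, ((2-fluorobenzyl)carbamoyl)methyl, with its hydrogen-bond donor and acceptor, does not bring the read-out back to a measured number. Replacing 2-cyanopyridin-4-yl with this group gives an at least 6.9-fold higher number from compound 1 to compound 3 (0.83 log units; beyond the scatter), in the same direction as an at least 7.5-fold higher number from compound 1 to compound 2 (0.87 log units; beyond the scatter), so two different replacements of 2-cyanopyridin-4-yl now point the same way. The step between compound 2 and compound 3 cannot be read, as both values are limits, and no order can be set between these two groups.

On these data alone, how far the true values of compound 2 and compound 3 lie beyond their limits remains open, and so does whether the fluorinated benzene ring they share matters, as compound 1 lacks it. Also open, as far as these compounds go, is whether a group on this nitrogen other than 2-cyanopyridin-4-yl can lower the number, such as a longer chain ending in an amine or a carboxylic acid, or an unsubstituted benzyl.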